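From acetamidoethyl amine to carboxypyrrolidine

The source may hold more compounds than are shown below. What is called first, only, known or untested is meant among the compounds shown, and "the series" means these compounds.

Going by the values given here, in a functional assay on B16-F10 cells (Mus musculus) for antiproliferative activity, read by CCK-8 assay, with a stated time of 48 h (a higher number here means a weaker inhibitor, a lower number a stronger inhibitor), compound 2 `COc1ccc(/C=C\c2cc(OC)c(OC)c(OC)c2)cc1OCc1ccc(CNCCNC(C)=O)cc1` gives 2500 nM as the only actual number so far. Compound 1 `COc1ccc(/C=C\c2cc(OC)c(OC)c(OC)c2)cc1OCc1ccc(CNC(C)(C)C(=O)O)cc1` reads > 10000 nM as a limit of the assay and not a number.

Compound 3 `COc1ccc(/C=C\c2cc(OC)c(OC)c(OC)c2)cc1OCc1ccc(CN2CC[C@@H](C(=O)O)C2)cc1` is still unmeasured, and its structural difference from compound 2 is 3-carboxypyrrolidin-1-yl in place of (2-acetamidoethyl)amino on a saturated chain carbon bound to an aromatic carbon with 3-carboxypyrrolidin-1-yl in place of (2-acetamidoethyl)amino on a saturated chain carbon bound to an aromatic carbon.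

Among the compounds with values here, one measured step bears on this change. It is an at least 4.0-fold lower number from compound 1 to compound 2 (0.60 log units; beyond the scatter) where 2-acetamidoethyl replaced 1-carboxy-1-methylethyl on an amine nitrogen. Compound 3 carries a carboxy group as compound 1 does, so the expectation is a partial or full reversal of that step in this assay and a move toward a higher number. The carboxy group sits on a ring in compound 3 and on an open chain in compound 1, which leaves the size of the move uncertain.

The expected change is a 3.2-fold higher number from compound 2 to compound 3 (0.51 log units; beyond the scatter) as a working estimate. For compound 3 the estimated value is 8000 nM within an expected range of 2800 nM to 25000 nM in this series.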

Compound 3, half-maximal inhibitory concentration: > 10000 nM
Compound 3: no number, only a limit; the forecaster's own chance of this, stated with the estimate: 50%; at least 1.2-fold (0.09 log units) between middle value and limit.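

In this assay, placing 3-carboxypyrrolidin-1-yl on a saturated chain carbon bound to an aromatic carbon gives an at least 4.0-fold higher number from compound 2 to compound 3 (0.60 log units; beyond the scatter), so a carboxy group carried on a five-membered ring does not restore the activity of compound 2. Among the compounds shown, both groups that carry a carboxy group, the open-chain one in compound 1 and the ring-borne one in compound 3, end at the assay limit, and no compound shown goes against this pairing, although three compounds are a narrow basis for it. The step between compound 1 and compound 3 cannot be read, and neither compound can be placed beyond the limit: the limit of > 10000 nM in this assay, at which 2 of the 3 values shown sit.

Compound 3 differs from compound 2 by losing the acetamide and the open chain and by gaining a ring and a carboxylic acid, so the compounds shown leave open which of these changes carries the step. An unsubstituted pyrrolidin-1-yl or a 3-(methoxycarbonyl)pyrrolidin-1-yl group at this place would separate the effect of the ring from that of the free carboxylic acid.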